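The compounds below may be only part of what the source reports. "The series", "measured", "known", "first", "only" and "open" are said of these compounds alone.

Compound 2, `CC(C)C1=C(N2CC2)C(=O)C=C(N2CC2)C1=O`, gives 5.37 in a functional assay on L1210 cells (Mus musculus), with a stated time of 12 days; a lower number here means a less potent compound, a higher number a more potent compound, by a factor of ten per unit of this negative logarithm. Among the two measured compounds it holds the higher of the two numbers, though its nearest neighbour, compound 1, `CC1=C(N2CC2)C(=O)C(C(C)C)=C(N2CC2)C1=O`, sits within the scatter of it: in this assay compound 1 gives 5.21. Going by the values given here, the one measured step, a number 0.16 log units higher from compound 1 to compound 2 (within the scatter), replaces a methyl with hydrogen on a double-bonded ring carbon of the shared core and changes nothing beyond the scatter.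

Compound 3, `CC(C)C1=C(N2CC2)C(=O)C(C(C)C)=C(N2CC2)C1=O`, is not yet measured. It differs from compound 2 by isopropyl in place of hydrogen on a double-bonded ring carbon. Among the compounds with values here, the only measured step that bears on this change runs in the opposite sense, removing a small alkyl group from a ring carbon, and it was flat; no measured step shows an isopropyl entering, so the size of the new group has no direct precedent here. On that basis the step from compound 2 to compound 3 is expected to be small, a number 0.07 log units lower from compound 2 to compound 3 (within the scatter), in no clear direction. Compound 3 is therefore estimated to give 5.3 in this assay, with a range from 4.85 to 5.75.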

Compound 3, logarithm of the reciprocal of the active concentration, log(1/C): 4.59
The estimate for compound 3 lay 0.71 log units above the measured number; measured number below the stated range.
By their numbers in this assay, from the lowest: compound 3; then compounds 1 and 2 (each within the scatter of the next).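

In this assay, the double-bonded ring carbon three ring bonds from the ring atom that bears an isopropyl group proves sensitive to what it carries: isopropyl in place of hydrogen brings a number 0.78 log units lower from compound 2 to compound 3 (beyond the scatter), and isopropyl in place of methyl brings a number 0.62 log units lower from compound 1 to compound 3 (beyond the scatter). The earlier exchange of methyl and hydrogen on this carbon had shown no change beyond the scatter, so the two smaller substituents could not be told apart, and only isopropyl sets its compound apart from the other two in this set of three. The data shown offer nothing that accounts for this loss of potency.

Going by these compounds, what remains open is whether the fall belongs to isopropyl alone or already begins with an ethyl group, and whether a longer chain such as n-butyl would take the number lower still. On these data alone, it is also open whether a group of another kind on this carbon, such as an amine or a methoxy group, would keep the number of compound 2 or lose it as isopropyl does.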